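The compounds below may be only part of what the source reports. "The series", "measured", "known", "first", "only" and "open" are said of these compounds alone.

compound 1, `CCOC(=O)C1=Cc2ccccc2OC1(OCc1cn(CC(=O)Nc2ccc(OC)cc2)nn1)C(F)(F)F`: 28100 nM
compound 2, `O=C(O)C1=Cc2ccccc2OC1(OCc1cc(-c2ccc([N+](=O)[O-])cc2)no1)C(F)(F)F`: > 150000 nM
compound 3, `CCOC(=O)C1=Cc2ccccc2OC1(OCc1cc(-c2ccc([N+](=O)[O-])cc2)no1)C(F)(F)F`: > 150000 nM

These three compounds share one core and were tested in a functional assay on MCF7 cells (Homo sapiens) for inhibition, read by MTT assay, with a stated time of 24 h; a lower number here means a stronger inhibitor, a higher number a weaker inhibitor. Compound 1 gives a measured number, 28100 nM. For compound 2 the result is only a limit of the assay, > 150000 nM. For compound 3 the result is likewise only a limit, > 150000 nM. Compound 2 therefore stands at the weak end of what the numbers show, without a measured value of its own. For the measured compounds named here, its only neighbour that differs in one place is compound 3, and the step that the two limits leave unreadable from compound 2 to compound 3 stays unreadable because of the limit of > 150000 nM in this assay, at which 2 of the 3 values shown sit.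

Compound 4, `O=C(O)C1=Cc2ccccc2OC1(OCc1cc(-c2cccc(C(F)(F)F)c2)no1)C(F)(F)F`, is not yet measured. It differs from compound 2 by 3-(trifluoromethyl)phenyl in place of 4-nitrophenyl on an aromatic carbon. No measured step bears on a change at this place; the one step shown alters a different part of the molecule and is itself unreadable. Going by the values given here, the numbers thus give no direction and no size for the step. The expected step of a number no higher from compound 2 to compound 4 (the limit leaves the size open) is none beyond the scatter. Compound 4 is therefore estimated at 150000 nM, within a range from 40000 nM to 600000 nM, and most probably the assay will again report only a limit.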

Compound 4, half-maximal inhibitory concentration: > 150000 nM
Compound 4 gave a limit, no number; the forecaster's own chance of this, stated with the estimate: 70%; the middle value sits exactly at the limit.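

Compound 2 and compound 4 each give only a limit in this assay, so no new step can be read between them: the limit of > 150000 nM in this assay, at which 3 of the 4 values shown sit.

The compounds shown leave open whether 3-(trifluoromethyl)phenyl in place of 4-nitrophenyl changes the inhibition at all, and if it does, in which direction and by how much.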